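Compound 3 to compound 4: replacing isobutyl

The source may report more compounds than this note shows. Statements on the series, on what has been measured and on what is new or still open speak of the compounds shown alone.

Measured in a physicochemical assay for lipophilicity, read by HPLC, at pH 7.4; a higher number here means a more lipophilic compound, a lower number a more polar compound:
- compound 1 `O=C(O)CCn1c(=O)oc2cc(OCC3CCC3)c(Cl)cc21` gives 2.9
- compound 2 `O=C(O)CCn1c(=O)oc2cc(Cl)c(Cl)cc21` gives 1.61
- compound 3 `CC(C)Cc1cc2oc(=O)n(CCC(=O)O)c2cc1Cl` gives 3.03

Compound 3 and compound 1 sit within the scatter of each other, and both lie well clear of compound 2. The next compound is compound 4 `C[C@@H](Oc1cc2oc(=O)n(CCC(=O)O)c2cc1Cl)c1ncco1`, and the change is a group of 8 heavy atoms (5 carbon, 1 nitrogen, 2 oxygen; one five-membered aromatic ring with 2 hetero atoms) in place of a group of 4 heavy atoms (4 carbon; no ring), on an aromatic carbon. The entering group is joined through oxygen, as cyclobutylmethoxy is in compound 1.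

That link matters little on its own, since the swap of cyclobutylmethoxy for isobutyl is small: a number 0.13 log units higher from compound 1 to compound 3 (within the scatter). Substituent changes at this carbon can still move the number a long way, as in a number 1.29 log units lower from compound 1 to compound 2 (beyond the scatter) and a number 1.42 log units higher from compound 2 to compound 3 (beyond the scatter). Among the compounds with values here, no measured compound carries a five-membered aromatic ring with 2 hetero atoms, so the direction rests on the structural change alone. In this assay a large downward step is expected, somewhat short of the step to compound 2. The expected step is a number 1.03 log units lower from compound 3 to compound 4 (beyond the scatter). For compound 4 the estimated value is 2, with an expected range of 1.6 to 2.5.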

Compound 4, distribution coefficient: 1.11
Estimate against measurement, compound 4: 0.89 log units above; measured number outside the range, below it.
By their numbers in this assay, from the lowest: compound 4; then compound 2; then compounds 1 and 3 (each within the scatter of the next).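

In this assay, the group with the five-membered aromatic ring gives the largest downward step at this aromatic carbon so far (a number 1.92 log units lower from compound 3 to compound 4 (beyond the scatter)), and it falls below even the single chlorine (a number 0.50 log units lower from compound 2 to compound 4 (beyond the scatter)), so across these compounds the number does not follow the size of the group. Joining through oxygen does not by itself keep the number high, since replacing the cyclobutylmethyl part on that same oxygen gives a large fall (a number 1.79 log units lower from compound 1 to compound 4 (beyond the scatter)). Nothing measured here accounts for these steps.

The compounds shown leave open how much of the fall belongs to the five-membered aromatic ring and how much to the branched carbon with its defined stereocentre. A phenyl ring on the same oxygen, or a benzyloxy group, would help separate the two.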